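A few compounds are considered here, and "the series" means these few. Any claim that something is new, unique, unknown or untested is made for them only; others in the source may bear on it.

Three compounds sharing one core have been run in an assay on blood for inhibition of Polyunsaturated fatty acid 5-lipoxygenase (Homo sapiens), tested at 10 uM; on this read-out higher numbers stand for a stronger effect at the one concentration tested and lower numbers for a weaker effect. Compound 1 `O=C1OC(c2ccccc2)C(c2ccc(O)cc2)=C1O` gives 0% in this assay. Compound 3 `O=C1OC(c2cc(O)cc(O)c2)C(c2ccc(O)cc2)=C1O` gives 0%, level with compound 1 at the digits shown, and the two stand together as the lowest of the three numbers. Compound 2 `O=C1OC(c2cc(OCc3ccccc3)cc(OCc3ccccc3)c2)C(c2ccc(O)cc2)=C1O` gives 32%, a number beyond the scatter above compound 1. Compound 4 `O=C1OC(c2ccc(O)cc2)C(c2ccc(O)cc2)=C1O` has not been measured. It differs from compound 1 by hydroxy in place of hydrogen on an aromatic carbon. Going by the values given here, no directly comparable step exists among the measured compounds, but the hydroxy-bearing compound 3 gives 0%, level with compound 1. The step is expected to be a number 3 percentage points higher from compound 1 to compound 4 (within the scatter), none beyond the scatter. Compound 4 is estimated at 3%, with a range from 0% to 15%.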

Compound 4, a percentage reported as activity, at one concentration (the size of the read-out at that concentration, not a potency): 0%
The estimate for compound 4 lay 3 percentage points above the measured number, within the range that was stated.
By their numbers in this assay, from the lowest: compounds 1, 3 and 4 (each within the scatter of the next); then compound 2.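

In this assay, going by these compounds alone, hydroxy in place of hydrogen on an aromatic carbon, para to a large group, gives no change at the digits printed from compound 1 to compound 4 (within the scatter), the first step that can be read at a single place. At the one concentration tested, this hydroxy therefore brings no measurable gain, with compound 4 at 0% in this read-out. Nothing available gives a reason for this result.

On these data alone, whether a methoxy group, an amine or a carboxylic acid at this position would raise the read-out remains open.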